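Swapping thiophene for furan on a bis(hydroxyphenyl)pyridine core

The compounds below may be only part of what the source reports. "The series", "measured", "known", "first", "only" and "open" are said of these compounds alone.

Three compounds share one core and differ in how the hydroxyphenyl arms are arranged. Compound 1 `Oc1cccc(-c2cc(-c3cccs3)cc(-c3ccccc3O)n2)c1` gives 9300 nM in a functional assay on DU-145 cells (Homo sapiens) for cytotoxicity, read by CCK-8 assay; a lower number here means a stronger inhibitor, a higher number a weaker inhibitor. Compound 2 `Oc1cccc(-c2cc(-c3cccs3)cc(-c3cccc(O)c3)n2)c1` gives 1630 nM in this assay, and compound 3 `Oc1ccc(-c2cc(-c3cccs3)cc(-c3cccc(O)c3)n2)cc1` gives 1890 nM. Compound 2 holds the lowest number of the three, though only the gap to compound 1 is beyond the scatter: the step of a 5.7-fold lower number from compound 1 to compound 2 (0.76 log units; beyond the scatter) and the step of a 4.9-fold lower number from compound 1 to compound 3 (0.69 log units; beyond the scatter) are both modest, while the step of a 1.2-fold higher number from compound 2 to compound 3 (0.06 log units; within the scatter) is within the scatter.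

Compound 4 `Oc1cccc(-c2cc(-c3ccco3)cc(-c3cccc(O)c3)n2)c1` keeps both 3-hydroxyphenyl groups of compound 2 and changes only the five-membered ring: furan-2-yl in place of thiophen-2-yl on an aromatic carbon. Within the data shown here, none of the measured steps touches this ring; all three move a hydroxyl around a phenyl arm, and the two arms of compound 2 are left unchanged here. Among the measured compounds shown here, with no measured step bearing on the change, the expectation for this assay is a step from compound 2 to compound 4 of a 1.1-fold higher number from compound 2 to compound 4 (0.04 log units; within the scatter), not beyond the scatter. Compound 4 is therefore estimated at 1800 nM, with a range from 700 nM to 4600 nM.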

Compound 4, half-maximal inhibitory concentration: 2150 nM
The estimate for compound 4 lay 1.2-fold (0.08 log units) below the measured number; the range from low to high includes it.
By their numbers in this assay, from the lowest: compounds 2, 3 and 4 (each within the scatter of the next); then compound 1.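

Until now, every measured step had moved a hydroxyl around a phenyl arm, and the position opposite the ring nitrogen had stayed fixed. In this assay, furan-2-yl in place of thiophen-2-yl gives a 1.3-fold higher number from compound 2 to compound 4 (0.12 log units; within the scatter), so with both 3-hydroxyphenyl groups held constant, this exchange of one five-membered aromatic ring for another does not move the number beyond the scatter. No evidence is available to explain this outcome.

The compounds shown leave open whether the position tolerates groups of a different kind, such as an amine, a carboxylic acid or a longer alkyl chain, in place of these rings. They also leave open whether furan-2-yl would give a similar result alongside the hydroxyl arrangements of compound 1 or compound 3.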